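The source may report more compounds than this note shows. Statements on the series, on what has been measured and on what is new or still open speak of the compounds shown alone.

Compound 1 `CC(C)=CCc1cc(C2=C(O)/C(=C/c3ccc4c(c3)CC(O)C(C)(C)O4)OC2=O)c(O)cc1O` in a functional assay on J774.1 cells (Mus musculus), read by LDH release, with a stated time of 1 h, in the presence of a further agent that is not named here; a higher number here means a weaker inhibitor, a lower number a stronger inhibitor: 2800 nM
Compound 2 `CC(C)=CCc1cc(C2=C(O)/C(=C/c3ccc(O)c(CC(O)C(C)(C)O)c3)OC2=O)c(O)cc1O` in this assay: 7400 nM
Compound 3 `CC(C)=CCc1cc(/C=C2\OC(=O)C(c3ccc(O)cc3O)=C2O)ccc1O` in this assay: 2400 nM

Of the compounds shown here, three sharing a common core have been measured. Compound 3 gives the lowest number of the three; its nearest neighbour is compound 1, whose number is within the scatter of repeated measurements, so the two cannot be told apart on these data. Compound 2 lies further off, beyond the scatter, with the higher number.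

Compound 4 `CC(C)=CCc1cc(/C=C2\OC(=O)C(c3cc(CCC(C)(C)O)c(O)cc3O)=C2O)ccc1O` has not yet been measured. It differs from compound 3 in one place: 3-hydroxy-3-methylbutyl in place of hydrogen on an aromatic carbon. For the measured compounds named here, a comparable group sits on the other ring in compound 1 and compound 2, but in those compounds the rest of the structure also differs, so no single-change step is available to guide the expectation. Because compound 1 gives 2800 nM and compound 2 gives 7400 nM, both of which sit at or above compound 3, a small step towards a higher number is expected, a 1.5-fold higher number from compound 3 to compound 4 (0.16 log units; within the scatter), possibly within the scatter. Compound 4 is estimated at 3500 nM, with a likely range from 1200 nM to 10000 nM.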

Compound 4, half-maximal inhibitory concentration: 3300 nM
For compound 4 the middle estimate is 1.1-fold (0.03 log units) above the measured one; the range from low to high includes it.
By their numbers in this assay, from the lowest: compounds 3, 1 and 4 (each within the scatter of the next); then compound 2.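

In this assay, placing a 3-hydroxy-3-methylbutyl group on this aromatic carbon, ortho to one hydroxy group and para to another, gives a 1.4-fold higher number from compound 3 to compound 4 (0.14 log units; within the scatter) and so leaves the number indistinguishable from that of the parent. For the compounds shown here, this is the first reading of the chain as a single change, since compound 1 and compound 2 carry a comparable group only on the other ring and differ elsewhere too. The position therefore takes a chain of this size without a detectable loss in this assay, but nothing measured here explains that outcome.

From the compounds shown here alone, whether the hydroxy group of the chain matters remains open, as a plain 3-methylbutyl chain would test this. It is also unknown how an amine, a carboxylic acid or a longer chain would fare on this carbon.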